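The source may hold more compounds than are shown below. What is called first, only, known or untested is meant among the compounds shown, and "the series" means these compounds.

In a functional assay on PC-3 cells (Mus musculus) for cytotoxicity against PC-3 (Homo sapiens) (a higher number here means a weaker inhibitor, a lower number a stronger inhibitor), compound 3 `CCN(CC)c1c([N+](=O)[O-])cc(S(=O)(=O)Nc2ccccc2)cc1[N+](=O)[O-]`, which carries diethylamino, gives 56000 nM, the highest number of the three measured compounds. The change to compound 4 `CCCCN(CCCC)c1c([N+](=O)[O-])cc(S(=O)(=O)Nc2ccccc2)cc1[N+](=O)[O-]` is dibutylamino in place of diethylamino on an aromatic carbon, ortho to two nitro groups. Among the compounds with values here, no measured step isolates this change. Within the data shown here, the one measured step, a 1.4-fold lower number from compound 1 to compound 2 (0.14 log units; within the scatter), is chloro in place of methyl on an aromatic carbon, so it concerns another part of the molecule. The only hint is indirect. Compound 1 `CCCN(CCC)c1c([N+](=O)[O-])cc(S(=O)(=O)Nc2cccc(C)c2)cc1[N+](=O)[O-]`, at 25000 nM, and compound 2 `CCCN(CCC)c1c([N+](=O)[O-])cc(S(=O)(=O)Nc2cccc(Cl)c2)cc1[N+](=O)[O-]`, at 18000 nM, both carry dipropylamino and both show lower numbers than compound 3. However, each also bears a methyl or chloro group that compound 3 lacks, so that comparison mixes two changes. A moderate move toward a lower number is therefore expected, with wide uncertainty. The expected step is a 3.1-fold lower number from compound 3 to compound 4 (0.49 log units; beyond the scatter). For compound 4 the estimated value is 18000 nM, with an expected range from 6000 nM to 50000 nM.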

Compound 4, half-maximal inhibitory concentration: 13000 nM
For compound 4 the middle estimate is 1.4-fold (0.14 log units) above the measured one; the measured number falls inside the stated range.
By their numbers in this assay, from the lowest: compounds 4, 2 and 1 (each within the scatter of the next); then compound 3.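

In this assay, within the data shown here, dibutylamino in place of diethylamino gives a 4.3-fold lower number from compound 3 to compound 4 (0.63 log units; beyond the scatter), the first step that isolates this position on an otherwise unchanged core. Among these compounds, the group on this aromatic carbon, ortho to two nitro groups, therefore does shift the number beyond the scatter, unlike the one earlier step, the exchange of methyl for chloro elsewhere in the molecule, which stayed within it. No measurement among these data accounts for this step.

Dipropylamino occurs only together with a methyl or chloro group, so these compounds cannot show whether the number follows chain length evenly. Also open, from the compounds shown here alone, is what a longer chain such as dihexylamino, a ring amine such as piperidine, or a chain ending in a carboxylic acid would give at this position.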